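Trifluoromethyl in Place of Methoxy on a Shared Core

The compounds below may be only part of what the source reports. "The series", "measured", "known", "first", "only" and "open" are said of these compounds alone.

Among the measured compounds shown here, compound 2 `COc1cccc2c1nnn2CC1CC1` is one of two compounds measured in an ADME assay on microsomes from liver (Mus musculus, strain NMRI) for metabolic stability, tested at 2.5 uM; a lower number here means slower removal, a higher number faster removal of the compound. In this assay compound 2 gives 8.3 mL/min/g. Its only neighbour among the numbers shown is compound 1 `Brc1cccc2c1nnn2CC1CC1`, and in this assay compound 1 gives 7.7 mL/min/g. The two lie within the scatter of each other, the step being a 1.1-fold higher number from compound 1 to compound 2 (0.03 log units; within the scatter). Compound 3 `FC(F)(F)c1cccc2c1nnn2CC1CC1` is not yet measured. It differs from compound 2 in one place: trifluoromethyl in place of methoxy on an aromatic carbon. For the measured compounds named here, only the single measured step bears on this change, and it is a different swap at the same carbon, so it shows merely that exchanging the group there has not so far moved the number beyond the scatter. On that basis no step beyond the scatter is expected from compound 2 to compound 3, a step of a 1.0-fold lower number from compound 2 to compound 3 (0.02 log units; within the scatter). Compound 3 is therefore estimated at 8 mL/min/g, with a range from 4 mL/min/g to 16 mL/min/g.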

Compound 3, intrinsic clearance in a liver preparation (reported as CLH), per the amount of preparation that the assay uses: 1.4 mL/min/g
Beside the measured number, compound 3's estimate is 5.7-fold (0.76 log units) above it; the measured number lies below the stated range.
By their numbers in this assay, from the lowest: compound 3; then compounds 1 and 2 (each within the scatter of the next).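

The earlier pair left it possible that the group on this aromatic carbon made little difference in this assay, but that held only for methoxy and bromo: trifluoromethyl brings a 5.9-fold lower number from compound 2 to compound 3 (0.77 log units; beyond the scatter) and, measured against bromo, a 5.5-fold lower number from compound 1 to compound 3 (0.74 log units; beyond the scatter). The number at this position therefore does respond to the group placed there, and compound 3 stands apart from compound 1 and compound 2, which lie within the scatter of each other. Nothing measured here bears on the reason for this drop.

As far as these compounds go, whether the drop is particular to trifluoromethyl or would also appear with another group on this carbon, such as a nitrile, an amine or a carboxylic acid, stays open. So does whether the same exchange would give a step of this size on a different core.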